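Swapping tert-butyl for iodo on a phenylurea

This account rests on a few compounds, and the source may have more. Where it says the series, first, only, none or still open, it means among the compounds named here.

Compound 1 `CC(C)c1ccc(NC(=O)N[C@H](C)c2ccccc2)cc1` gives 99% in an ADME assay on the whole organism with Oryza sativa as the target, tested at 0.1 uM; on this read-out higher numbers stand for a weaker effect at the one concentration tested and lower numbers for a stronger effect
Compound 2 `C[C@@H](NC(=O)Nc1ccccc1C(C)(C)C)c1ccccc1` gives 100% in this assay
Compound 3 `C[C@H](NC(=O)Nc1ccccc1C(C)(C)C)c1ccccc1` gives 101% in this assay

Compound 3 stands among three numbers that all lie within the usual scatter of one another, so none of the three can be set apart. Among the measured compounds shown here, the single measured step, a number 1 percentage points higher from compound 2 to compound 3 (within the scatter), also stayed within the scatter, which fits (the fact that compounds 2 and 3 differ only in the configuration as drawn). Compound 4 `C[C@H](NC(=O)Nc1ccccc1I)c1ccccc1` has not yet been measured in this assay; it differs from compound 3 by iodo in place of tert-butyl on an aromatic carbon. For the measured compounds named here, no measured step exchanges one group for a different one, so this change has no close precedent among the three compounds. Compound 4 is expected to stay close to its neighbours, with an estimated step of a number 3 percentage points lower from compound 3 to compound 4 (within the scatter). The estimate for compound 4 is 98%, within a range from 85% to 106%.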

Compound 4, a percentage reported as activity, at one concentration (the size of the read-out at that concentration, not a potency): 99%
Compound 4: middle estimate off by 1 percentage points, on the low side, and the stated range covers the measured number.
By their numbers in this assay, from the lowest: compounds 1, 4, 2 and 3 (each within the scatter of the next).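

Exchanging tert-butyl for iodo on the aromatic carbon, ortho to a large group, gives a number 2 percentage points lower from compound 3 to compound 4 (within the scatter) in this assay. Among the compounds shown here, this is the first exchange of one group for a different one here, and the read-out does not separate the two groups, although iodo carries fewer heavy atoms. Nothing measured here bears on why the two groups read alike.

From the compounds shown here alone, whether an amine or a carboxylic acid on this aromatic carbon would also leave the number in place stays open. So does whether any change to the shared core would move the read-out at all.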